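A few compounds are considered here, and "the series" means these few. Any claim that something is new, unique, unknown or untested is made for them only; others in the source may bear on it.

Measured so far, in a functional assay on A549 cells (Homo sapiens) for antiproliferative activity, read by MTT assay; on this read-out lower numbers stand for stronger inhibition and higher numbers for weaker inhibition:

compound 1, `COc1cc2c(Oc3ccc(NC(=O)Nc4ccccc4)cc3)ccnc2cc1OCCCCCCC(=O)NO`: 1650 nM
compound 2, `COc1cc2c(Oc3ccc(NC(=O)Nc4ccccc4F)cc3)ccnc2cc1OCCCCCCC(=O)NO`: 870 nM
compound 3, `COc1cc2c(Oc3ccc(NC(=O)NNC(=O)c4ccccc4)cc3)ccnc2cc1OCCCCCCC(=O)NO`: 2820 nM

Compounds 1 and 2 share a core and differ in one place: fluoro in place of hydrogen on an aromatic carbon. That change gave a 1.9-fold lower number from compound 1 to compound 2 (0.28 log units; within the scatter), so the two values cannot be told apart with confidence.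

Compound 3 carries a different core. Its difference from compound 1 is benzamido in place of phenyl on an amide-type nitrogen, and the step was a 1.7-fold higher number from compound 1 to compound 3 (0.23 log units; within the scatter). Against compound 2 the gap is larger, a 3.2-fold higher number from compound 2 to compound 3 (0.51 log units; beyond the scatter).

Compound 4, `COc1cc2c(Oc3ccc(NC(=O)NNC(=O)c4ccccc4F)cc3)ccnc2cc1OCCCCCCC(=O)NO`, has not been measured. It stands to compound 3 as compound 2 stands to compound 1: the change is fluoro in place of hydrogen on an aromatic carbon. The description of where the new group sits reads the same in both cases, so this is the same change, only carried out on the core of compound 3 rather than on that of compound 1, the two cores differing as described above.

Among the compounds with values here, since the one earlier example of this change, a 1.9-fold lower number from compound 1 to compound 2 (0.28 log units; within the scatter), stayed within the usual scatter, a step of similar size is expected here: a 1.8-fold lower number from compound 3 to compound 4 (0.25 log units; within the scatter) is the estimated step, resting on that single precedent. Within the data shown here, with only one example, the direction is uncertain. Compound 4 is therefore expected to give about 1600 nM in this assay , most likely between 700 nM and 3600 nM.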

Compound 4, half-maximal inhibitory concentration: 2420 nM
Compound 4: the middle estimate sits 1.5-fold (0.18 log units) below what was measured, and the stated range covers the measured number.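

In this assay the new step is a 1.2-fold lower number from compound 3 to compound 4 (0.07 log units; within the scatter), and when it is set beside the earlier example, fluoro in place of hydrogen behaves alike on the two cores: the same change on two cores in this assay, a 1.9-fold lower number (0.28 log units; within the scatter) from compound 1 to compound 2 and a 1.2-fold lower number (0.07 log units; within the scatter) from compound 3 to compound 4, 1.6-fold (0.21 log units) apart, within the scatter of two such steps

Within the data shown here, neither step lies beyond the usual scatter, so the agreement shows only that this change moved the number by no clear amount on either core; it does not show that the change has a real effect of the same size on both, and two examples cannot establish a rule for the series. The steps that link the two cores tell the same story, since a 1.5-fold higher number from compound 1 to compound 4 (0.17 log units; within the scatter) cannot be told apart from no change, while a 2.8-fold higher number from compound 2 to compound 4 (0.44 log units; beyond the scatter) is a modest gap, about as large as the one already seen between the fluorinated compound 2 and compound 3.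

On these data alone, whether chloro or methoxy in place of the fluoro would give a step beyond the scatter on either core remains open. As far as these compounds go, it is also open whether a longer chain would change how the two cores compare.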